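Replacing the 4-chlorophenyl group of compound 2

The source may report more compounds than this note shows. Statements on the series, on what has been measured and on what is new or still open speak of the compounds shown alone.

In a functional assay on HeLa cells (Homo sapiens) for cytotoxicity, read by ELISA, with a stated time of 4 days (on this read-out higher numbers stand for weaker inhibition and lower numbers for stronger inhibition), compound 1 `Cc1ccsc1-c1cc(-c2ccc(Cl)o2)cc(-c2cccc(Cl)c2)n1` gives 24800 nM and compound 2 `Cc1ccsc1-c1cc(-c2ccc(Cl)o2)cc(-c2ccc(Cl)cc2)n1` gives 29300 nM. With only these two numbers available, compound 2 stands within the scatter of compound 1. The next analogue is compound 3 `Cc1ccsc1-c1cc(-c2ccc(Cl)o2)cc(-c2cccnc2)n1`, with pyridin-3-yl in place of 4-chlorophenyl on an aromatic carbon. For the measured compounds named here, the only measured step, a 1.2-fold higher number from compound 1 to compound 2 (0.07 log units; within the scatter), swaps 3-chlorophenyl for 4-chlorophenyl and so bears on this change only indirectly. Going by the values given here, no measured step covers the entry of a ring with a hetero atom, so the data give no direction, and no step beyond the scatter is expected, though with wide uncertainty. The estimated step is a 1.2-fold lower number from compound 2 to compound 3 (0.07 log units; within the scatter). For compound 3 the expected value is 25000 nM, with an estimated range from 8000 nM to 70000 nM.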

Compound 3, half-maximal inhibitory concentration: > 50000 nM
Compound 3 gave a limit, no number; the forecaster's own chance of this, stated with the estimate: 15%; middle value at least 2.0-fold (0.30 log units) away from the limit.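

Compound 3 gives a limit of this assay, not a number: the limit of > 50000 nM in this assay, at which 1 of the 3 values shown sits. With pyridin-3-yl at this position, the step for its replacement of 4-chlorophenyl is an at least 1.7-fold higher number from compound 2 to compound 3 (0.23 log units; that floor lies within the scatter), and the step for its replacement of 3-chlorophenyl is an at least 2.0-fold higher number from compound 1 to compound 3 (0.30 log units; that floor lies within the scatter). Both are floors within the scatter, so they establish no loss, but they do show that this first ring with a hetero atom at the position brings no lower number than either chlorophenyl ring.

As far as these compounds go, how far the true value of compound 3 lies beyond the limit remains open, and so does the real size of both steps. Also open, from the compounds shown here alone, is whether an unsubstituted phenyl, a primary amine or a carboxylic acid at this position would move the read-out beyond the scatter in either direction.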